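This account rests on a few compounds, and the source may have more. Where it says the series, first, only, none or still open, it means among the compounds named here.

Measured compounds in an assay on BTI cells for inhibition of Amine oxidase [flavin-containing] B (Homo sapiens), read by fluorescence, with stated times of 30 min and 1 h; a lower number here means a stronger inhibitor, a higher number a weaker inhibitor:
compound 1 `C#CCNC1CCc2c(OCCCN3CCN(c4cccc5c4ccn5Cc4cccc(Cl)c4)CC3)cccc21` gives > 1000 nM, which is a limit of the assay.
compound 2 `C#CCNC1CCc2c(OCCCCCN3CCN(c4cccc5c4ccn5Cc4cccc(Cl)c4)CC3)cccc21` gives 460 nM.
compound 3 `C[C@H](NCc1ccc(OCCCCCN2CCN(c3cccc4c3ccn4Cc3cccc(Cl)c3)CC2)cc1)C(N)=O` gives > 1000 nM, which is a limit of the assay.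

Compound 3 stands at the limit of > 1000 nM in this assay, at which 2 of the 3 values shown sit. Within this set a numerical value exists only for compound 2 in this assay; compound 3 and compound 1 carry no number, and no measured pair isolates a single change, so no measured step is available to calibrate any modification in this assay.

Compound 4 `C[C@H](NCc1ccc(OCCCCCN2CCN(c3cccc4c3ccn4S(=O)(=O)c3ccccc3)CC2)cc1)C(N)=O` differs from compound 3 by phenylsulfonyl in place of 3-chlorobenzyl on an aromatic nitrogen. Within the data shown here, no measured compound pair shows this exchange, so its size and direction in this assay are not known from the data.

Since compound 3 is reported only as a limit, the step that the limit leaves unreadable from compound 3 to compound 4 is expected to be small, or none beyond the usual scatter, and the most likely outcome for compound 4 is again a limit rather than a number. Compound 4 is estimated at 3000 nM in this assay, with a range from 700 nM to 15000 nM.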

Compound 4, half-maximal inhibitory concentration: > 1000 nM
Compound 4 ended at the assay's limit; the forecaster's own chance of this, stated with the estimate: 65%; the middle value does not contradict the limit.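

In this assay compound 4 gives > 1000 nM, which is a limit of the assay, and compound 3 also stands at a limit, so no step can be read between compound 3 and compound 4: the limit of > 1000 nM in this assay, at which 3 of the 4 values shown sit.

The compounds shown leave open the size and direction of phenylsulfonyl in place of 3-chlorobenzyl on an aromatic nitrogen in this assay.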